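From compound 1 to compound 4: a change on sulfonyl sulfur

A few compounds are considered here, and "the series" means these few. Any claim that something is new, unique, unknown or untested is made for them only; others in the source may bear on it.

Compound 1 `CC(C)(C)C1CCN(S(=O)(=O)c2ccc(NC(=O)c3ccc([N+](=O)[O-])o3)cc2)CC1` is the starting point of this step. In an ADME assay on IMR-90 cells (Homo sapiens) for cytotoxicity, read by CellTiter-Blue, with a stated time of 46 h (a lower number here means that less compound is needed, a higher number that more compound is needed for the effect), compound 1 gives > 25000 nM as its reading, which is a limit and not a number. Compound 2 `O=C(Nc1ccc(S(=O)(=O)N2CCC3(CCCCC3)CC2)cc1)c1ccc([N+](=O)[O-])o1` gives > 25000 nM as its reading, again a limit. Compound 3 `O=C(Nc1ccc(S(=O)(=O)N2CCC(O)CC2)cc1)c1ccc([N+](=O)[O-])o1` gives > 25000 nM as its reading, also a limit. Among the measured compounds shown here, compound 1 therefore stands with the other two, and the series so far offers only the limit of > 25000 nM in this assay, at which 3 of the 3 values shown sit, as its common reading, with no compound going against it.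

Compound 4 `N=C1CCN(S(=O)(=O)c2ccc(NC(=O)c3ccc([N+](=O)[O-])o3)cc2)CC1` carries 4-iminopiperidin-1-yl in place of 4-(tert-butyl)piperidin-1-yl on a sulfonyl sulfur, and the counted difference is 4-iminopiperidin-1-yl in place of 4-(tert-butyl)piperidin-1-yl on a sulfonyl sulfur here.

For the measured compounds named here, the one measured step that bears on this change is a step that the two limits leave unreadable from compound 1 to compound 3, which also replaces the tert-butyl-bearing end of compound 1 and has no readable size. Compound 2 adds a further change at the same sulfonyl sulfur and remains at the limit. No step beyond the scatter is therefore expected in this assay, in either direction. The expected outcome is a number no higher from compound 1 to compound 4 (the limit leaves the size open) as an estimate. Compound 4 is estimated at 25000 nM, with an expected range from 12000 nM to 50000 nM and a reading at the limit as the likeliest result.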

Compound 4, half-maximal effective concentration: > 25000 nM
Compound 4: no number, only a limit; the forecaster's own chance of this, stated with the estimate: 80%; the middle value sits exactly at the limit.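

In this assay compound 4 gives > 25000 nM, which is a limit and not a number, so the steps to compound 4 from compound 1 and from compound 3 cannot be read. The compounds shown leave open whether any group on the sulfonyl sulfur gives a readable number, as the series still offers only: the limit of > 25000 nM in this assay, at which 4 of the 4 values shown sit.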